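Removing the Indole Methyl: Compound 2 to Compound 4

This account rests on a few compounds, and the source may have more. Where it says the series, first, only, none or still open, it means among the compounds named here.

Measured compounds:
Compound 1, `COc1cc(C(C2=C(O)C(=O)c3ccccc3C2=O)c2c[nH]c3ccc(Br)cc23)cc(OC)c1OC`, gives 13000 nM in a functional assay on ECa-109 cells (Homo sapiens) for cytotoxicity, read by MTT assay, with a stated time of 48 h; a lower number here means a stronger inhibitor, a higher number a weaker inhibitor.
Compound 2, `Cc1[nH]c2ccccc2c1C(C1=C(O)C(=O)c2ccccc2C1=O)c1ccc(Cl)cc1`, gives 14300 nM in this assay.
Compound 3, `Cc1[nH]c2ccccc2c1C(C1=C(O)C(=O)c2ccccc2C1=O)c1ccc([N+](=O)[O-])cc1`, gives 6000 nM in this assay.

Compound 2 has the highest number of the three, meaning the weakest inhibition. Compound 1 sits within the usual scatter of it, so no order between those two can be claimed. Within the data shown here, compound 3 lies clearly lower: the step of a 2.4-fold lower number from compound 2 to compound 3 (0.38 log units; beyond the scatter), and it is the only step among the measured compounds in which just one group changes.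

Compound 4, `O=C1C(O)=C(C(c2ccc(Cl)cc2)c2c[nH]c3ccccc23)C(=O)c2ccccc21`, differs from compound 2 in one place: hydrogen in place of methyl on an aromatic carbon. Among the measured compounds shown here, none of the measured steps touches this position; the only step known, from compound 2 to compound 3, changes a group on a different ring and says nothing about the methyl on the indole. For the measured compounds named here, with no comparable step to lean on, the estimate for compound 4 is anchored on compound 2 itself, and the expected step is a 1.0-fold lower number from compound 2 to compound 4 (0.01 log units; within the scatter), that is, none beyond the scatter. Compound 4 is therefore expected to give about 14000 nM in this assay, with a range from 6000 nM to 33000 nM that allows for a shift in either direction.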

Compound 4, half-maximal inhibitory concentration: 45800 nM
Compound 4: middle estimate off by 3.3-fold (0.51 log units), on the low side, and the stated range ends below it.
By their numbers in this assay, from the lowest: compound 3; then compounds 1 and 2 (each within the scatter of the next); then compound 4.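

Even a single methyl counts at this position: the change from 2-methyl-1H-indol-3-yl to 1H-indol-3-yl gives a 3.2-fold higher number from compound 2 to compound 4 (0.51 log units; beyond the scatter) in this assay, and a higher number here means weaker inhibition. Among these compounds, the earlier single-change step, a 2.4-fold lower number from compound 2 to compound 3 (0.38 log units; beyond the scatter), concerned a group on a different ring, so this is the first reading at the aromatic carbon next to the ring nitrogen, and with the chloro group unchanged, the compound that keeps the methyl is the stronger inhibitor of this pair. Nothing available explains why this methyl matters, and the step records only that its removal goes with a higher number.

Going by these compounds, it remains open whether an ethyl group, a longer chain or an amine on this same carbon would lower the number further, leave it unchanged or raise it, so the result cannot yet be extended beyond methyl and hydrogen. On these data alone, it is also open whether replacing methyl with hydrogen would produce a similar step with nitro in place of chloro, a question that would need a partner of compound 3 carrying hydrogen at this carbon.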